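Switching the Side-Chain Group on a Shared Core

A few compounds are considered here, and "the series" means these few. Any claim that something is new, unique, unknown or untested is made for them only; others in the source may bear on it.

Of the compounds shown here, two on a shared core have been measured, differing only in the group on one aromatic carbon. Compound 1 `CC(=O)c1c(C)nc2c(OCc3ccccc3)cccn12` carries an acetyl there and in a functional assay on the whole organism (stomach) for inhibition, with Canis familiaris (Canis lupus familiaris) as the target, at a dose of 5 mg/kg by the intravenous route (a lower number here means a weaker effect, a higher number a stronger effect of the compound at the dose given), compound 1 gives 9%. Compound 2 `CCSCc1c(C)nc2c(OCc3ccccc3)cccn12` carries an (ethylsulfanyl)methyl instead, and in this assay compound 2 gives 0%. The step of a number 9 percentage points lower from compound 1 to compound 2 (within the scatter) is the only one recorded. Compound 2 thus stands lowest of the two numbers, with compound 1 as its nearest neighbour, higher but within the scatter, so the two cannot be ranked.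

Compound 3 `CCCCC(=O)OCc1c(C)nc2c(OCc3ccccc3)cccn12` is the next compound, differing from compound 2 in one place: (butylcarbonyl)oxy in place of ethylsulfanyl on a saturated chain carbon bound to an aromatic carbon. Going by the values given here, the one measured step that bears on this change is the swap at the same aromatic carbon from compound 1 to compound 2, which stayed within the scatter and left both compounds near the bottom of the scale. On that basis the step of a number 5 percentage points higher from compound 2 to compound 3 (within the scatter) is expected to remain within the scatter. Compound 3 is therefore estimated at 5% in this assay, with a range from 0% to 20%.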

Compound 3, a percentage reported as inhibition, in the whole organism at one dose (the size of the read-out at that dose, not a potency): 96%
Compound 3: the middle estimate sits 91 percentage points below what was measured; measured number outside the range, above it.
By their numbers in this assay, from the lowest: compounds 2 and 1 (each within the scatter of the next); then compound 3.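

With compound 3, the group on this saturated chain carbon proves able to decide the outcome in this assay: replacing ethylsulfanyl with (butylcarbonyl)oxy gives a number 96 percentage points higher from compound 2 to compound 3 (beyond the scatter). The comparison with the acetyl compound points the same way, with ((butylcarbonyl)oxy)methyl in place of acetyl on the aromatic carbon giving a number 87 percentage points higher from compound 1 to compound 3 (beyond the scatter), so the earlier pair, which could not be ranked, did not show the full reach of changes at this aromatic carbon. No measurement is available here that accounts for this large rise.

The compounds shown leave open whether the rise belongs to the (butylcarbonyl)oxy group as a whole or to one part of it, a question that a hydroxyl, an acetyloxy with its shorter chain, or an amine on the same saturated chain carbon would help to settle. From the compounds shown here alone, it also remains open how compound 3 behaves at other doses, since this assay gives the size of the effect at a single dose and not a potency.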